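The source may hold more compounds than are shown below. What is called first, only, known or untested is meant among the compounds shown, and "the series" means these compounds.

Compound 1 `COc1cccc(OC)c1OCCNCCOc1ccccc1OCc1ccccc1` stands with the highest number of the three measured in a functional assay on PC-3 cells (Homo sapiens) for cytotoxicity, read by sulforhodamine B assay (a higher number here means a weaker inhibitor of growth, a lower number a stronger inhibitor of growth), where compound 1 gives 26900 nM. Compound 2 `COc1cccc(OC)c1OCCNCCOc1ccccc1OCc1ccccc1Cl` gives 5400 nM in this assay, and compound 3 `COc1cccc(OC)c1OCCNCCOc1ccccc1OCc1ccc(Cl)cc1` gives 2400 nM. Both chloro replacements lowered the number: a 5.0-fold lower number from compound 1 to compound 2 (0.70 log units; beyond the scatter) and an 11-fold lower number from compound 1 to compound 3 (1.05 log units; beyond the scatter), with a 2.3-fold lower number from compound 2 to compound 3 (0.35 log units; beyond the scatter) between the two chloro isomers. Compound 4 `CCOc1ccc(COc2ccccc2OCCNCCOc2c(OC)cccc2OC)cc1` differs from compound 1 by ethoxy in place of hydrogen on an aromatic carbon. Within the data shown here, no measured step introduces ethoxy, but the step of an 11-fold lower number from compound 1 to compound 3 (1.05 log units; beyond the scatter), which also swaps a hydrogen on the benzyl ring, bears on it most directly. A lower number is therefore expected for compound 4, though by a smaller margin given the different group. For compound 4 the expected step is a 3.8-fold lower number from compound 1 to compound 4 (0.58 log units; beyond the scatter). Compound 4 is estimated at 7000 nM, within 2500 nM to 20000 nM.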

Compound 4, concentration for 50% growth inhibition: 5200 nM
Compound 4: middle estimate off by 1.3-fold (0.13 log units), on the high side, within the range that was stated.
By their numbers in this assay, from the lowest: compound 3; then compounds 4 and 2 (each within the scatter of the next); then compound 1.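

Ethoxy, a group with oxygen and a two-carbon chain, also lowers the number at this aromatic carbon in this assay, so this effect is not confined to chloro (a 5.2-fold lower number from compound 1 to compound 4 (0.71 log units; beyond the scatter)). The choice of group still matters, since ethoxy in place of chloro gives (a 2.2-fold higher number from compound 3 to compound 4 (0.34 log units; beyond the scatter)). The 4-ethoxyphenyl and 2-chlorophenyl variants cannot be told apart (a 1.0-fold lower number from compound 2 to compound 4 (0.02 log units; within the scatter)).

No evidence here accounts for these steps. Going by these compounds, whether an amine, a carboxylic acid or a longer alkoxy chain on this carbon would lower the number further remains open.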